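Benzyl variation on the acylsemicarbazone series

The source may hold more compounds than are shown below. What is called first, only, known or untested is meant among the compounds shown, and "the series" means these compounds.

Measured so far:
compound 1 `CN(C)Cc1ccc2nc(NC(=O)N/N=C/c3cn(Cc4ccc(Cl)cc4Cl)c4ccccc34)sc2c1`: 950 nM
compound 2 `CCN(CC)Cc1ccc2nc(NC(=O)N/N=C/c3cn(Cc4ccc(Cl)cc4Cl)c4ccccc34)sc2c1`: 1080 nM

In a functional assay on NCI-H460 cells (Homo sapiens) for cytotoxicity, read by MTT assay, with a stated time of 72 h (a lower number here means a stronger inhibitor, a higher number a weaker inhibitor), compound 1 gives 950 nM and stands lowest of the two numbers, though its nearest neighbour, compound 2, is within the scatter. Among the compounds with values here, the one measured step, a 1.1-fold higher number from compound 1 to compound 2 (0.06 log units; within the scatter), concerns only the amine on the shared core and says nothing about the benzyl group.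

Compound 3 `CN(C)Cc1ccc2nc(NC(=O)N/N=C/c3cn(Cc4ccc(C(C)(C)C)cc4)c4ccccc34)sc2c1` is not yet measured. It differs from compound 1 in this way: 4-(tert-butyl)phenyl in place of 2,4-dichlorophenyl on a saturated chain carbon bound to an aromatic nitrogen. Within the data shown here, no measured pair bears on this change, so there is no basis for expecting a step in either direction beyond the scatter; the range has to be kept wide.

Compound 3 is expected to give 1400 nM, with a range from 350 nM to 5600 nM, which means an expected step of a 1.5-fold higher number from compound 1 to compound 3 (0.17 log units; within the scatter).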

Compound 3, half-maximal inhibitory concentration: 810 nM
Compound 3: the middle estimate sits 1.7-fold (0.24 log units) above what was measured; the range from low to high includes it.
By their numbers in this assay, from the lowest: compounds 3, 1 and 2 (each within the scatter of the next).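

In this assay, within the data shown here, the exchange of 2,4-dichlorobenzyl for 4-(tert-butyl)benzyl gives a 1.2-fold lower number from compound 1 to compound 3 (0.07 log units; within the scatter) and so offers the first reading at this position, which the amine step could not supply. Two chlorine atoms leave and a tert-butyl group enters, taking the group from 8 to 10 heavy atoms, yet this pair stays within the scatter; that statement covers these two groups only. Nothing available bears on why these two groups read alike.

Still open, from the compounds shown here alone, is whether a benzyl group carrying a methoxy group or a carboxylic acid, or a longer chain between the phenyl ring and the aromatic nitrogen, would also stay within the scatter of compound 1. Also open, going by these compounds, is whether the diethylamino group of compound 2 reads the same alongside 4-(tert-butyl)benzyl.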